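This account rests on a few compounds, and the source may have more. Where it says the series, first, only, none or still open, it means among the compounds named here.

Compound 2, `CCCc1nc(-c2ccccc2)c(CNCCCN2CCN(c3ccccc3)CC2)o1`, is the one with the higher of the two numbers recorded so far: in an assay on HEK293 cells for inhibition of Voltage-dependent T-type calcium channel subunit alpha-1G (Homo sapiens), read by fluorescence, tested at 10 uM (a higher number here means more inhibition at the concentration tested (going by the name of the read-out), a lower number less inhibition), compound 2 gives 43.7%, and compound 1, `CCCc1nc(-c2ccccc2)c(CNCCCN2CCN(c3cccc(OC)c3)CC2)o1`, gives 36.4%. Among the measured compounds shown here, the one step measured between them, a number 7.3 percentage points higher from compound 1 to compound 2 (within the scatter), is small and stays inside the usual scatter of this kind of measurement. The new compound 3, `CCCc1nc(-c2ccccc2)c(CNCCCN2CCN(c3ccccc3C)CC2)o1`, differs from compound 2 in a single place: methyl in place of hydrogen on an aromatic carbon. For the measured compounds named here, no measured step shows what a methyl group entering this ring does; the only step available concerns a methoxy group leaving the same ring, and that step changed little. Taken as the sole guide, it suggests a change of no more than the scatter. The expected step of a number 0.3 percentage points higher from compound 2 to compound 3 (within the scatter) is therefore small, and compound 3 is estimated at 44%, with a likely range from 24% to 64%.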

Compound 3, a percentage reported as inhibition, at one concentration (the size of the read-out at that concentration, not a potency): 54.5%
Compound 3: the middle estimate sits 10.5 percentage points below what was measured, within the range that was stated.
By their numbers in this assay, from the lowest: compounds 1 and 2 (each within the scatter of the next); then compound 3.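

Placing a methyl on this aromatic carbon, ortho to a large group, gives a number 10.8 percentage points higher from compound 2 to compound 3 (beyond the scatter) in this assay and is the first change on this ring to go beyond the scatter. Exchanging the whole 3-methoxyphenyl for 2-methylphenyl on the amine nitrogen in the ring gives a number 18.1 percentage points higher from compound 1 to compound 3 (beyond the scatter) and so separates two compounds in a series whose first pair, compound 1 and compound 2, lay within the scatter of each other. Nothing available explains why the methyl changes the number in this way.

Going by these compounds, whether an ethyl group, a chlorine atom or a methoxy group at this same place would give a similar step remains open. Also open, on these data alone, is whether a methyl elsewhere on this ring would do the same.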